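The compounds below may be only part of what the source reports. "The series", "measured", "known", "first", "only" and "open" are said of these compounds alone.

Measured so far:
- compound 1, `COc1ccc([C@H]2CC(=O)N(Cc3cccc(C#N)c3)C2)cc1OC1CCCC1`: > 10000 nM
- compound 2, `COc1ccc([C@H]2CC(=O)N(c3cccc(N(C)C)c3)C2)cc1OC1CCCC1`: > 10000 nM
- compound 3, `COc1ccc([C@H]2CC(=O)N(c3ccc(C)c(N)c3)C2)cc1OC1CCCC1`: > 10000 nM

In a functional assay on HEK293 cells (Homo sapiens) for cytotoxicity (on this read-out lower numbers stand for higher toxicity in this test and higher numbers for lower toxicity in this test), compound 1 gives > 10000 nM, which is a limit of the assay and not a number. Compound 2 likewise gives > 10000 nM, again only a limit. Compound 3 gives > 10000 nM, a limit as well. The three measured steps are therefore all unreadable: a step that the two limits leave unreadable from compound 1 to compound 2, a step that the two limits leave unreadable from compound 1 to compound 3 and a step that the two limits leave unreadable from compound 2 to compound 3. What the series does show is the limit of > 10000 nM in this assay, at which 3 of the 3 values shown sit — every substituent so far on the amide-type nitrogen in the ring has left the shared core of compound 1 without measurable toxicity in this assay.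

Compound 4, `COc1ccc([C@H]2CC(=O)N(c3cccc(N)c3C)C2)cc1OC1CCCC1`, is not yet measured. It differs from compound 1 in one place: 3-amino-2-methylphenyl in place of 3-cyanobenzyl on an amide-type nitrogen in a ring. The closest measured neighbours, compound 3 with its 3-amino-4-methylphenyl group and compound 2 with its 3-(dimethylamino)phenyl group, both sit at the limit, and the change from a benzyl to a phenyl on that nitrogen has so far produced no readable step. Compound 4 is therefore expected to show no step beyond the scatter, a step that the limit leaves unreadable from compound 1 to compound 4, most likely reported again as a limit. The estimate for compound 4 in this assay is 15000 nM, within 7000 nM to 40000 nM.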

Compound 4, half-maximal cytotoxic concentration: > 10000 nM
Compound 4: a limit, no number; the forecaster's own chance of this, stated with the estimate: 85%; the middle value does not contradict the limit.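

In this assay compound 4 gives > 10000 nM, a limit of the assay and not a number. Its steps from compound 1, compound 2 and compound 3 cannot be read, because all four compounds stand at one limit: the limit of > 10000 nM in this assay, at which 4 of the 4 values shown sit.

The compounds shown leave open what number lies behind each limit, and whether any group on that nitrogen would give a readable value.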